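This account rests on a few compounds, and the source may have more. Where it says the series, first, only, none or still open, it means among the compounds named here.

Compound 2 `COc1ccc(Cn2nnc(-c3ccccc3)c2C(=O)N[C@@H](C)c2ccc(C(=O)O)cc2)cc1OC` gives 119 nM in a functional assay on CHO cells for antagonist activity at prostaglandin E2 receptor EP4 subtype (Homo sapiens), read by calcium flux, with a stated time of 15 min; a lower number here means a stronger inhibitor, a higher number a weaker inhibitor. Within the data shown here, that is the higher of the two numbers recorded: compound 1 `COc1ccc(Cn2nnc(-c3ccccc3)c2C(=O)N[C@@H](C)c2ccc(C(=O)O)cc2)cc1F` gives 29.8 nM in this assay, and the step of a 4.0-fold higher number from compound 1 to compound 2 (0.60 log units; beyond the scatter), methoxy in place of fluoro on an aromatic carbon, is the only step measured so far. Compound 3 `C[C@H](NC(=O)c1c(-c2ccccc2)nnn1CC1CCCCC1)c1ccc(C(=O)O)cc1` differs from compound 2 by cyclohexyl in place of 3,4-dimethoxyphenyl on a saturated chain carbon bound to an aromatic nitrogen, which one bond further out reads as 3,4-dimethoxybenzyl to cyclohexylmethyl. Among the measured compounds shown here, no measured step bears directly on exchanging this aromatic ring for a saturated one. For the measured compounds named here, the single step available, a 4.0-fold higher number from compound 1 to compound 2 (0.60 log units; beyond the scatter), shows only that changing substituents on this ring moved the number modestly. Without direct precedent, compound 3 is expected to stay in the same general region, and the step of a 1.3-fold higher number from compound 2 to compound 3 (0.10 log units; within the scatter) is an estimate carrying wide uncertainty. Compound 3 is therefore estimated at 150 nM in this assay, with a range from 40 nM to 600 nM.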

Compound 3, half-maximal inhibitory concentration: > 10000 nM
Compound 3 was reported as a limit (the forecaster's own chance of this, stated with the estimate: 10%); middle value at least 66-fold (1.82 log units) from the limit.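

In this assay compound 3 is recorded only as a limit, not as a number: the limit of > 10000 nM in this assay, at which 1 of the 3 values shown sits.

Replacing 3,4-dimethoxyphenyl with cyclohexyl on this saturated chain carbon bound to an aromatic nitrogen gives an at least 84-fold higher number from compound 2 to compound 3 (1.92 log units; beyond the scatter), and replacing 3-fluoro-4-methoxyphenyl with cyclohexyl gives an at least 330-fold higher number from compound 1 to compound 3 (2.52 log units; beyond the scatter). Among these compounds, the earlier compounds showed only that a substituent change on the aromatic ring moves the number modestly, whereas these steps show that exchanging the whole ring for a saturated one costs far more at this position.

The exchange removes the aromatic ring and its substituents together, and the compounds shown do not separate the two. From the compounds shown here alone, how a plain benzyl or a 4-methoxycyclohexylmethyl group would stand here remains open.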